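The source may report more compounds than this note shows. Statements on the series, on what has been measured and on what is new or still open speak of the compounds shown alone.

Measured compounds:
compound 1, `C=CCn1c(=O)/c(=C\c2ccc(Cl)c(Cl)c2)[nH]c(=O)/c1=C\c1ccccc1OC`: "not active" (no number reported)
compound 2, `C=CCn1c(=O)/c(=C\c2ccccc2C(F)(F)F)[nH]c(=O)/c1=C\c1ccccc1OC`: 9500 nM

For the measured compounds named here, in a functional assay on Huh-7 cells (Homo sapiens) for cytotoxicity, read by CCK-8 assay, with a stated time of 72 h (on this read-out lower numbers stand for stronger inhibition and higher numbers for weaker inhibition), compound 2 gives 9500 nM, the only number recorded for this series. Compound 1, by contrast, is reported in this assay simply as "not active" (no number reported), with no figure attached. Going by the values given here, compound 2 therefore stands as the single measured value, and nothing can be said about its rank against compound 1 beyond the fact that compound 1 carries no number.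

Compound 3, `C=CCn1c(=O)/c(=C\c2cccc(C)c2)[nH]c(=O)/c1=C\c1ccccc1OC`, differs from compound 2 by 3-methylphenyl in place of 2-(trifluoromethyl)phenyl on a double-bonded chain carbon bound to an aromatic carbon. Among the compounds with values here, no measured pair in this set shows that exchange, so the size of the step is not known from data; it is expected to be modest, with a drift toward weaker inhibition of a 1.6-fold higher number from compound 2 to compound 3 (0.20 log units; within the scatter). In this assay compound 3 is expected to give about 15000 nM, with a range from 5000 nM to 45000 nM, and a real chance that only a limit is reported.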

Compound 3, half-maximal inhibitory concentration: 21400 nM
The estimate for compound 3 lay 1.4-fold (0.15 log units) below the measured number; the range from low to high includes it.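

In this assay, for the compounds shown here, 3-methylphenyl in place of 2-(trifluoromethyl)phenyl on a double-bonded chain carbon bound to an aromatic carbon gives a 2.3-fold higher number from compound 2 to compound 3 (0.35 log units; beyond the scatter) and provides the first measured step, showing that the number responds to a change at this place. The exchange alters both the substituent and where it sits on the aromatic ring, so this single step cannot separate the two changes. Nothing available bears on the cause of the step.

The compounds shown leave open whether trifluoromethyl or methyl, or the place each occupies, accounts for the difference. They also leave open how an amine or a carboxylic acid on this aromatic ring would read, and whether the allyl group on the shared core can be exchanged for a longer chain.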